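This account rests on a few compounds, and the source may have more. Where it says the series, first, only, none or still open, it means among the compounds named here.

Compound 1 `COc1cc(C2=NN(C(C)=O)C(c3c(Cl)cccc3Cl)O2)cc(OC)c1OC` gives -1.4%.
Compound 2 `COc1ccc(OC)c(/C=N/NC(=O)c2cc(OC)c(OC)c(OC)c2)c1` gives 0.1%.
Compound 3 `COc1cc(C(=O)N/N=C/c2c(Cl)cccc2Cl)cc(OC)c1OC` gives 0.9%.

All three numbers come from a functional assay on BGC-823 cells (Homo sapiens) for antiproliferative activity, read by MTT assay, tested at 1 uM; a higher number here means a stronger effect of the compound at the concentration tested, a lower number a weaker effect. Of the three numbers compound 1 has the smallest, yet compound 2, its nearest neighbour, and compound 3, its furthest, both sit within the usual scatter of it, so no real difference between any two of them can be read.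

Compound 4 `COc1cc(C2=NN(C(C)=O)C(c3cccc(C(F)(F)F)c3)O2)cc(OC)c1OC` has not been measured yet. It arises from compound 1 by a single change: 3-(trifluoromethyl)phenyl in place of 2,6-dichlorophenyl on a saturated ring carbon. Within the data shown here, no measured pair shows a comparable step, so there is nothing to suggest a move in either direction; the step of a number 1.4 percentage points higher from compound 1 to compound 4 (within the scatter) is expected to stay within the scatter. Compound 4 is therefore estimated at 0%, with a range from -9% to 10%.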

Compound 4, a percentage reported as inhibition, at one concentration (the size of the read-out at that concentration, not a potency): 27.9%
Compound 4: middle estimate off by 27.9 percentage points, on the low side; the measured number lies above the stated range.
By their numbers in this assay, from the lowest: compounds 1, 2 and 3 (each within the scatter of the next); then compound 4.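

Putting 3-(trifluoromethyl)phenyl in place of 2,6-dichlorophenyl on the saturated ring carbon gives, in this assay, a number 29.3 percentage points higher from compound 1 to compound 4 (beyond the scatter). Among these compounds, this shows that the group at this carbon can change the read-out on the shared core, which the earlier compounds, all within the scatter of one another, could not show. No measurement available explains this step.

Still open, going by these compounds, is whether the rise comes from the trifluoromethyl group or from the loss of the two chlorines. Also open, on these data alone, is what an unsubstituted phenyl, or a phenyl carrying an amine or a carboxylic acid, would do at this carbon.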